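Exchanging One Phenyl Group on Compound 3

The compounds below may be only part of what the source reports. "The series", "measured", "known", "first", "only" and "open" are said of these compounds alone.

Of the compounds shown here, three sharing one core have been measured in an ADME assay on NHDF cells (Homo sapiens) for cytotoxicity, read by MTT assay, with a stated time of 72 h; on this read-out higher numbers stand for weaker inhibition and lower numbers for stronger inhibition. There, compound 1 `COc1ccc(/C=C2\CCC/C(=C\c3ccccc3Cl)C2=O)cc1OC` gives 21600 nM, compound 2 `COc1ccc(/C=C2\CCC/C(=C\c3ccc(Br)cc3)C2=O)cc1OC` gives 13100 nM, and compound 3 `COc1cccc(/C=C2\CCC/C(=C\c3ccc(OC)c(OC)c3)C2=O)c1` gives 11600 nM. Compound 3 therefore stands within the scatter of both other compounds, and these three values cannot be ranked.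

The next compound, compound 4 `COc1ccc(/C=C2\CCC/C(=C\c3ccc(Cl)c(Cl)c3)C2=O)cc1OC`, has not yet been measured. Its difference from compound 3 is 3,4-dichlorophenyl in place of 3-methoxyphenyl on a double-bonded chain carbon bound to a double-bonded ring carbon.

Three measured steps involve exchanges at this same place: a 1.9-fold lower number from compound 1 to compound 3 (0.27 log units; within the scatter), a 1.1-fold lower number from compound 2 to compound 3 (0.05 log units; within the scatter) and a 1.6-fold lower number from compound 1 to compound 2 (0.22 log units; within the scatter). All three lie within the scatter, across 2-chlorophenyl, 4-bromophenyl and 3-methoxyphenyl. For the measured compounds named here, no measured compound carries the 3,4-dichlorophenyl group, so this evidence is indirect.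

On these three steps, no shift beyond the scatter is expected in this assay. The expected step is a 1.2-fold higher number from compound 3 to compound 4 (0.08 log units; within the scatter), too small to give a direction with any confidence. For compound 4 the estimated value is 14000 nM, with an expected range from 7000 nM to 28000 nM.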

Compound 4, half-maximal inhibitory concentration: 10100 nM
Compound 4: middle estimate off by 1.4-fold (0.14 log units), on the high side, within the range that was stated.
By their numbers in this assay, from the lowest: compounds 4, 3, 2 and 1 (each within the scatter of the next, the first and the last beyond it).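

For the compounds shown here, the 3,4-dichlorophenyl group gives the first step at this place on a double-bonded chain carbon bound to a double-bonded ring carbon that passes the scatter in this assay, a modest one with 3,4-dichlorophenyl in place of 2-chlorophenyl (a 2.1-fold lower number from compound 1 to compound 4 (0.33 log units; beyond the scatter)). Against the other two neighbours the same group can't be told apart (a 1.1-fold lower number from compound 3 to compound 4 (0.06 log units; within the scatter); a 1.3-fold lower number from compound 2 to compound 4 (0.11 log units; within the scatter)), so even swapping 3-methoxyphenyl, which has a hydrogen-bond acceptor, for a group with none gives no readable shift, and the four compounds form a flat run in which only the two ends stand apart. Nothing at hand accounts for these numbers.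

Going by these compounds, the groups at this place are all phenyl rings bearing chlorine, bromine or methoxy, so it stays open whether an amine, a carboxylic acid or a longer chain here would move the number clearly past the scatter. Going by these compounds alone, it also stays open whether the single step beyond the scatter would hold on repeat measurement, as it is the only one of its kind and is modest in size.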